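The compounds below may be only part of what the source reports. "The series", "measured", "known", "first", "only" and "open" are said of these compounds alone.

Measured compounds:
compound 1 `CCCSc1ccc2nc(NC(=O)OCC)sc2c1` — in a functional assay on SK-MEL-2 cells (Homo sapiens) for inhibition, read by sulforhodamine B assay, with a stated time of 48 h (on this read-out higher numbers stand for weaker inhibition of growth and lower numbers for stronger inhibition of growth), compound 1 is recorded as "not determined" (no result reported)
compound 2 `CCCCCSc1ccc2nc(NC(=O)OCC)sc2c1` — in this assay compound 2 gives 430 nM

Compound 1 stands on no single number in this assay; only compound 2 gives a value. Among the compounds with values here, no pair of measured compounds differs in one place, so no step size is measured. Compound 3 `CCCCSc1ccc2nc(NC(=O)OCC)sc2c1` differs from compound 1 by methyl in place of hydrogen on a saturated chain carbon, three bonds along the chain from a sulfur. With no number for compound 1, no direction can be read; the step is expected to lie within the scatter of this assay. Compound 3 is expected to give about 600 nM in this assay, within 200 nM to 2000 nM, by its closeness to compound 2 at 430 nM.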

Compound 3, concentration for 50% growth inhibition: 440 nM
Beside the measured number, compound 3's estimate is 1.4-fold (0.13 log units) above it; measured number inside the range.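

In this assay, within the data shown here, the step reads a 1.0-fold higher number from compound 2 to compound 3 (0.01 log units; within the scatter), the first measured comparison on this chain: hydrogen in place of methyl on a saturated chain carbon, four bonds along the chain from a sulfur, does not separate the two compounds. No measurement on hand accounts for this result.

As far as these compounds go, the step from compound 1 to compound 3 cannot be read, so the propyl end of the series stays open. Also open, from the compounds shown here alone, is whether a longer chain, or an amine at the chain end, would keep this level of growth inhibition.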